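The compounds below may be only part of what the source reports. "The series", "measured", "known", "first", "only" and "open" are said of these compounds alone.

Measured in a functional assay on NCI-H1299 cells (Homo sapiens) for antiproliferative activity, read by MTT assay, with a stated time of 72 h; a higher number here means a weaker inhibitor, a lower number a stronger inhibitor:
compound 1 `CCOC1=C(C(=O)c2ccccc2)C(c2ccc(Br)cc2)N(CCCn2ccnc2)C1=O` gives 28900 nM
compound 2 `CCCCOC1=C(C(=O)c2ccccc2)C(c2ccc(Br)cc2)N(CCCn2ccnc2)C1=O` gives 17100 nM
compound 3 `O=C(C1=C(Nc2ccccc2)C(=O)N(CCCn2ccnc2)C1c1ccc(Br)cc1)c1ccccc1` gives 21200 nM

Compound 3 stands second highest of the three numbers; its nearest neighbour is compound 2, a 1.2-fold higher number from compound 2 to compound 3 (0.09 log units; within the scatter), and the step of a 1.4-fold lower number from compound 1 to compound 3 (0.13 log units; within the scatter) is likewise within the scatter, so the three compounds cannot be told apart in this assay. Compound 4 `CCOc1ccc(NC2=C(C(=O)c3ccccc3)C(c3ccc(Br)cc3)N(CCCn3ccnc3)C2=O)cc1` differs from compound 3 by ethoxy in place of hydrogen on an aromatic carbon. For the measured compounds named here, no measured step touches the anilino ring: the step of a 1.7-fold lower number from compound 1 to compound 2 (0.23 log units; within the scatter) and the two steps already named all vary the group on the double-bonded ring carbon and all stay within the scatter. Nothing measured bears directly on this change, and no step beyond the scatter is expected in this assay, a 1.1-fold lower number from compound 3 to compound 4 (0.03 log units; within the scatter). Compound 4 is estimated at 20000 nM, with a range of 6000 nM to 60000 nM.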

Compound 4, half-maximal inhibitory concentration: 20000 nM
Compound 4: the middle estimate sits on the measured number at the digits printed, and the stated range covers the measured number.
By their numbers in this assay, from the lowest: compounds 2, 4, 3 and 1 (each within the scatter of the next).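

In this assay, for the compounds shown here, a 1.1-fold lower number from compound 3 to compound 4 (0.03 log units; within the scatter) is the first step that changes the anilino ring itself, and adding ethoxy at this aromatic carbon leaves the number within the scatter. With this substituted ring in place, a 1.2-fold higher number from compound 2 to compound 4 (0.07 log units; within the scatter) and a 1.4-fold lower number from compound 1 to compound 4 (0.16 log units; within the scatter) also stay within the scatter, so (4-ethoxyphenyl)amino cannot be told apart from butoxy or ethoxy on the double-bonded ring carbon. No evidence is available to explain these results.

Open, from the compounds shown here alone, is whether a carboxylic acid, an amine or a longer alkoxy chain at this aromatic carbon would give a step beyond the scatter.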